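The compounds below may be only part of what the source reports. "The series", "measured", "known", "first", "only" and "open" are said of these compounds alone.

Three compounds share a core carrying a naphthalenyl group and a formylmethyl group on a five-membered ring. In a functional assay on IMR-32 cells (Homo sapiens) for cytotoxicity, read by sulforhodamine B assay, with a stated time of 48 h (a lower number here means a stronger inhibitor, a higher number a weaker inhibitor), compound 1 `O=CCN1N=C(c2ccc3ccccc3c2)CC1c1cccc([N+](=O)[O-])c1` gives 3280 nM, compound 2 `COc1ccc(C2CC(c3ccc4ccccc4c3)=NN2CC=O)cc1OC` gives 1590 nM, and compound 3 `COc1ccc(C2CC(c3ccc4ccccc4c3)=NN2CC=O)cc1O` gives 1490 nM. For the measured compounds named here, compound 3 has the lowest number of the three, but its gap to compound 2 is within the scatter, so only the step of a 2.2-fold lower number from compound 1 to compound 3 (0.34 log units; beyond the scatter) counts as a real difference; the step of a 1.1-fold lower number from compound 2 to compound 3 (0.03 log units; within the scatter) does not. Compound 4 `O=CCN1N=C(c2ccc3ccccc3c2)CC1/C=C/c1ccccc1` differs from compound 3 by 2-phenylethenyl in place of 3-hydroxy-4-methoxyphenyl on a saturated ring carbon. Going by the values given here, no measured step swaps in a group like 2-phenylethenyl, so the two steps give little guidance. A step of about a 1.2-fold higher number from compound 3 to compound 4 (0.08 log units; within the scatter) is expected, within the scatter, and compound 4 is estimated at 1800 nM, between 700 nM and 4500 nM.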

Compound 4, half-maximal inhibitory concentration: 17200 nM
The estimate for compound 4 lay 9.6-fold (0.98 log units) below the measured number; the measured number lies above the stated range.
By their numbers in this assay, from the lowest: compounds 3 and 2 (each within the scatter of the next); then compound 1; then compound 4.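

For the compounds shown here, the substituent at this saturated ring carbon can matter far more than the earlier compounds suggested: swapping one substituted phenyl for another gave only a modest change, whereas 2-phenylethenyl gives a 12-fold higher number from compound 3 to compound 4 (1.06 log units; beyond the scatter) and a 5.2-fold higher number from compound 1 to compound 4 (0.72 log units; beyond the scatter) in this series. This group keeps one six-membered aromatic ring, but adds a double bond outside it and has no hydrogen-bond donors or acceptors, so several features change at once. Nothing available explains the rise.

On these data alone, it remains open which of these features matters. An unsubstituted phenyl or a saturated 2-phenylethyl chain at this carbon would help separate them.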